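A few compounds are considered here, and "the series" means these few. Any claim that something is new, unique, unknown or untested is made for them only; others in the source may bear on it.

Three compounds measured in a functional assay on NCI-H460 cells (Homo sapiens) for cytotoxicity, read by sulforhodamine B assay, with a stated time of 48 h (on this read-out higher numbers stand for weaker inhibition of growth and lower numbers for stronger inhibition of growth), set the scene. Compound 1 `Nc1nc(Cl)c2ncn(Cc3ccccc3CCl)c2n1` gives 37200 nM in this assay. Compound 2 `ClCc1cccc(Cn2cnc3nc(Cl)nc(Cl)c32)c1` gives 3090 nM in this assay, and compound 3 `ClCc1ccccc1Cn1cnc2ncnc(Cl)c21` gives 60300 nM in this assay. Among these three numbers compound 1 stands second highest: its value and that of compound 3 lie within the usual scatter of repeated measurements, so nothing separates them, whereas compound 2 sits well apart, with a number low enough to fall beyond that scatter.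

The step in question leads from compound 1 to compound 4 `ClCc1ccccc1Cn1cnc2c(Cl)ncnc21`, which has not yet been tested in this assay. The change is small: hydrogen in place of amino on an aromatic carbon. Only the amino group is removed, with a hydrogen atom taking its place on the core shared by the two compounds.

For the measured compounds named here, no pair of measured compounds differs in just this way, so nothing measured shows what such a removal does here. The expectation is therefore a cautious one: a step from compound 1 to compound 4 of about a 1.1-fold higher number from compound 1 to compound 4 (0.03 log units; within the scatter), that is, no change beyond the scatter. Compound 4 is expected to give about 40000 nM in this assay, with a plausible range from 12000 nM to 130000 nM.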

Compound 4, concentration for total growth inhibition: 44700 nM
Estimate against measurement, compound 4: 1.1-fold (0.05 log units) below; low and high end bracket the measured number.
By their numbers in this assay, from the lowest: compound 2; then compounds 1, 4 and 3 (each within the scatter of the next).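

In this assay the exchange of the amino group for hydrogen, on the aromatic carbon between two ring nitrogen atoms, gives a 1.2-fold higher number from compound 1 to compound 4 (0.08 log units; within the scatter) and so does not separate the two compounds. For the compounds shown here, this is the first direct reading of this position: in this one pair, the amino group can be exchanged for hydrogen with no difference that rises above the usual scatter of repeated measurements, although the earlier compounds alone could not show this. Nothing at hand explains why the two compounds read alike, and a single pair does not show that the amino group would count for as little on another compound.

Only amino and hydrogen are shown at this carbon, so it remains open whether a larger or differently built group, such as a methylamino group, a hydroxyl group or a methyl group, would read any differently. No compound shown differs from compound 2 in just one place, so its much lower number cannot yet be tied to any single group on the molecule.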